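Chloro in Place of Methyl: What Compound 4 Might Show

The compounds below may be only part of what the source reports. "The series", "measured", "known", "first", "only" and "open" are said of these compounds alone.

Three compounds have been measured in an assay on HL-60 cells for inhibition of glutathione S-transferase P (Homo sapiens), read by spectrophotometry, tested at 20 uM; on this read-out higher numbers stand for more inhibition at the one concentration tested (going by the name of the read-out) and lower numbers for less inhibition:
compound 1, `CCOc1ccc(/C=C2\CN(CC(=O)O)c3c(C)cccc3C2=O)cc1`, gives 42.4%
compound 2, `COc1ccc(/C=C2\CN(CC(=O)O)c3c(Cl)cccc3C2=O)c(OC)c1OC`, gives 23.6%
compound 3, `COc1ccc(/C=C2\CN(CC(=O)O)c3c(C)cccc3C2=O)c(OC)c1OC`, gives 1.57%

Compound 1 stands highest of the three, beyond the scatter from both others. The difference between the core of compound 1 and that of compound 3 is not broken down here. Between compound 3 and compound 2 the change is chloro in place of methyl on an aromatic carbon, and it gave a number 22 percentage points higher from compound 3 to compound 2 (beyond the scatter). Compound 4, `CCOc1ccc(/C=C2\CN(CC(=O)O)c3c(Cl)cccc3C2=O)cc1`, is not yet measured in this assay; it differs from compound 1 by chloro in place of methyl on an aromatic carbon, the same change at the same place. Because a number 22 percentage points higher from compound 3 to compound 2 (beyond the scatter) in that single pair, a step in the same direction is expected for compound 4, though one pair is a thin basis; the expected step is a number 15.6 percentage points higher from compound 1 to compound 4 (beyond the scatter). Compound 4 is estimated at 58%, between 40% and 78%.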

Compound 4, a percentage reported as inhibition, at one concentration (the size of the read-out at that concentration, not a potency): 59.1%
The estimate for compound 4 lay 1.1 percentage points below the measured number; the measured number falls inside the stated range.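

In this assay, chloro in place of methyl on an aromatic carbon gave a number 16.7 percentage points higher from compound 1 to compound 4 (beyond the scatter). Set beside the earlier pair, the change carried over from one core to the other with a step of matching size: the same change on two cores in this assay, a number 22 percentage points higher (beyond the scatter) from compound 3 to compound 2 and a number 16.7 percentage points higher (beyond the scatter) from compound 1 to compound 4, 5.3 percentage points apart, within the scatter of two such steps. This rests on two pairs alone, so it shows that the step held on these two cores, but it does not show that it would hold on any other core, and it gives no reason for the step.

The compounds shown carry only chloro or methyl at this place, so a bromo or a methoxy group there remains open. Also open, on these data alone, is an amide or a longer chain in place of the carboxylic acid.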